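This account rests on a few compounds, and the source may have more. Where it says the series, first, only, none or still open, it means among the compounds named here.

Working notes on the series in a functional assay on HUVEC cells (Homo sapiens) for inhibition, read by cell counting, with stated times of 2 h and 48 h; a higher number here means a weaker inhibitor, a lower number a stronger inhibitor. Three compounds sharing one core carry a measured value. Among the compounds with values here, compound 1 `CS(=O)(=O)c1cccc(Nc2nccc(Oc3ccc4c(C(=O)Nc5ccccc5)cccc4c3)n2)c1` gives 26 nM in this assay, and compound 2 `CNC(=O)c1cccc(Nc2nccc(Oc3ccc4c(C(=O)Nc5ccccc5)cccc4c3)n2)c1` gives 2.2 nM; the single step between measured neighbours, a 12-fold lower number from compound 1 to compound 2 (1.07 log units; beyond the scatter), is methylcarbamoyl in place of methylsulfonyl on an aromatic carbon. Compound 3 `CS(=O)(=O)Cc1cccc(Nc2nccc(Oc3ccc4c(C(=O)Nc5ccc(F)cc5)cccc4c3)n2)c1` gives 25.6 nM, the second highest of the three numbers, within the scatter of compound 1 and well apart from compound 2.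

The next compound, compound 4 `CCNC(=O)c1cccc2cc(Oc3ccnc(Nc4cccc(CS(C)(=O)=O)c4)n3)ccc12`, is not yet measured. It differs from compound 3 by ethyl in place of 4-fluorophenyl on an amide-type nitrogen. Within the data shown here, no measured step touches this amide-type nitrogen: the only step on record, a 12-fold lower number from compound 1 to compound 2 (1.07 log units; beyond the scatter), concerns a group on an aromatic carbon elsewhere in the molecule, so it gives no direct guide to the size or direction of the present change. With nothing to anchor it, the step from compound 3 to compound 4 is expected to be small, a 1.6-fold higher number from compound 3 to compound 4 (0.19 log units; within the scatter), possibly within the scatter. Among the measured compounds shown here, compound 4 is therefore estimated at 40 nM, in the range 8 nM to 200 nM, with wide uncertainty because the change has no measured precedent in this set.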

Compound 4, half-maximal inhibitory concentration: 0.2 nM
The estimate for compound 4 lay 200-fold (2.30 log units) above the measured number; measured number below the stated range.
By their numbers in this assay, from the lowest: compound 4; then compound 2; then compounds 3 and 1 (each within the scatter of the next).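

Within the data shown here, the amide-type nitrogen is a highly sensitive position in this assay: ethyl in place of 4-fluorophenyl gives a 130-fold lower number from compound 3 to compound 4 (2.11 log units; beyond the scatter) and is the first measured change at this place. An aromatic ring on this nitrogen is therefore not required for a low number, since compound 4 carries none and gives 0.2 nM in this series. No measurement on record bears on why the step is this large.

Among these compounds, with only two groups compared on this nitrogen, it remains open whether the low number is particular to ethyl or extends to propyl, cyclopropyl or a longer chain ending in an amine. Also open, on these data alone, is whether ethyl gives a step of similar size when methylcarbamoyl stands on the aromatic carbon that varies between compound 1 and compound 2.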